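From methoxy to trifluoromethyl on compound 2

The compounds below may be only part of what the source reports. "The series", "measured", "known", "first", "only" and "open" are said of these compounds alone.

Compound 1 `CCCCc1ccc2[nH]c(-c3ccc(C(F)(F)F)cc3)c(/C=N/NC(=O)c3ccccc3)c2c1` gives 300 nM
Compound 2 `CCCCc1ccc2[nH]c(-c3ccc(OC)cc3)c(/C=N/NC(=O)c3ccc(Cl)cc3)c2c1` gives 90 nM

In a functional assay on MDA-MB-231 cells (Homo sapiens) for antiproliferative activity, with a stated time of 4 days (a higher number here means a weaker inhibitor, a lower number a stronger inhibitor), compound 2 holds the lower of the two numbers (90 nM), and the gap up to compound 1 lies beyond the scatter. These two compounds differ in more than one place, so that gap cannot be assigned to a single group. Compound 3 `CCCCc1ccc2[nH]c(-c3ccc(C(F)(F)F)cc3)c(/C=N/NC(=O)c3ccc(Cl)cc3)c2c1` departs from compound 2 in one place only, with trifluoromethyl in place of methoxy on an aromatic carbon and the rest unchanged. For the measured compounds named here, no measured pair isolates this swap. Compound 1 also carries 4-(trifluoromethyl)phenyl and reads higher (300 nM), so a modest rise is expected, possibly no larger than the scatter. The expected step is a 1.9-fold higher number from compound 2 to compound 3 (0.28 log units; within the scatter) and remains an estimate. Compound 3 is estimated at 170 nM (range 70 nM to 400 nM).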

Compound 3, half-maximal inhibitory concentration: 329 nM
Compound 3: middle estimate off by 1.9-fold (0.29 log units), on the low side; low and high end bracket the measured number.
By their numbers in this assay, from the lowest: compound 2; then compounds 1 and 3 (each within the scatter of the next).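

In this assay the swap of methoxy for trifluoromethyl, on an aromatic carbon para to a large group, can now be read alone as a 3.7-fold higher number from compound 2 to compound 3 (0.56 log units; beyond the scatter) and so counts against trifluoromethyl at this position, with the rest of the molecule unchanged. Chloro in place of hydrogen on an aromatic carbon, with trifluoromethyl in the molecule, gives a 1.1-fold higher number from compound 1 to compound 3 (0.04 log units; within the scatter) and so shows no readable change. No supporting data bear on why methoxy and trifluoromethyl differ here.

For the compounds shown here, whether chloro has any effect alongside methoxy stays open, since its one step was read with trifluoromethyl present. The compounds shown also leave open how a hydroxyl, an ethoxy, a methyl or a dimethylamino group at this position would compare with methoxy.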